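The source may report more compounds than this note shows. Statements on the series, on what has been measured and on what is new or still open speak of the compounds shown alone.

Compound 1 `Cc1cccc(NC(=O)CN2CCC(c3ccc(Cl)cc3)CC2)c1`: 42400 nM
Compound 2 `CCc1cccc(NC(=O)CN2CCN(c3ccccn3)CC2)c1`: 370 nM

In an assay on cells for antagonist activity at D(4) dopamine receptor (Homo sapiens), read by luminescence and beta-arrestin recruitment, with a stated time of 90 min (on this read-out lower numbers stand for stronger inhibition and higher numbers for weaker inhibition), compound 1 gives 42400 nM, the higher of the two numbers shown, while compound 2 gives 370 nM. Compound 3 `Cc1ccc(C2CCN(CC(=O)Nc3cccc(C)c3)CC2)cc1` differs from compound 1 in one place: methyl in place of chloro on an aromatic carbon. For the measured compounds named here, the two measured compounds differ in many places at once, so their gap says nothing about this single swap, and no measured pair shows what it does. The step expected here, a 1.2-fold higher number from compound 1 to compound 3 (0.07 log units; within the scatter), stays within the usual scatter. For compound 3 the estimate is 50000 nM, between 15000 nM and 150000 nM.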

Compound 3, half-maximal inhibitory concentration: 7350 nM
Compound 3: middle estimate off by 6.8-fold (0.83 log units), on the high side, outside the stated range (below it).
By their numbers in this assay, from the lowest: compound 2; then compound 3; then compound 1.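

Replacing the 4-chlorophenyl group with 4-methylphenyl is not a neutral exchange at this position: in this assay, it gives a 5.8-fold lower number from compound 1 to compound 3 (0.76 log units; beyond the scatter). This is the only single-place comparison among the compounds shown, and it places the methyl compound on the stronger side of the chloro compound. Nothing available accounts for the step.

As far as these compounds go, whether a methoxy group, an amine or a carboxylic acid on this aromatic carbon would give a lower or a higher number remains open. A single pair also cannot show whether the same swap would act alike on another core.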